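This account rests on a few compounds, and the source may have more. Where it says the series, first, only, none or still open, it means among the compounds named here.

The measured compounds and their results in an ADME assay on HEp-2 cells (Homo sapiens) for cytotoxicity, read by CCK-8 assay, with a stated time of 6 days; a lower number here means that less compound is tolerated, a higher number that more compound is tolerated:

Compound 1 `NCCNc1cc(N2CCN(C(=O)C3(c4ccccc4)CC3)CC2)nc2ccccc12` — > 100000 nM, a limit of the assay.
Compound 2 `CS(=O)(=O)N1CCN(c2cc(NCCN)c3ccccc3n2)CC1` — > 100000 nM, a limit of the assay.
Compound 3 `NCCNc1cc(N2CCN(c3ccc(Cl)cc3)CC2)nc2ccccc12` — 6600 nM.

Compound 1 stands at a limit in this assay, so no number of its own is known for it. Compound 2 also sits at a limit, as the limit of > 100000 nM in this assay, at which 2 of the 3 values shown sit, records. Compound 3 is the only one of the three with a measured number. Going by the values given here, the single step between measured compounds that differ in one place runs an at least 15-fold lower number from compound 2 to compound 3 (1.18 log units; beyond the scatter), with 4-chlorophenyl in place of methylsulfonyl on an amine nitrogen in a ring. That change touches the amine nitrogen in the ring directly, whereas the change now at issue sits on the carbonyl carbon attached to that nitrogen.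

The unmeasured compound 4 `CC(C)CC(=O)N1CCN(c2cc(NCCN)c3ccccc3n2)CC1` differs from compound 1 as follows: isobutyl in place of 1-phenylcyclopropyl on a carbonyl carbon. Compound 1, which carries the larger 1-phenylcyclopropyl on the carbonyl carbon, already sits at the limit, and the measured step bears only indirectly on a change at the carbonyl carbon. Compound 4 is therefore expected to remain at the limit as well. For compound 4 the estimated value in this assay is 150000 nM, in a range from 50000 nM to 400000 nM. The expected step that the limit leaves unreadable from compound 1 to compound 4 is estimated to stay within the scatter.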

Compound 4, half-maximal cytotoxic concentration: > 100000 nM
Compound 4: no number, only a limit; the forecaster's own chance of this, stated with the estimate: 75%; the middle value is on the limit's open side.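

Compound 4 stands at a limit of this assay and has no number of its own, which makes it a further compound at the same ceiling: the limit of > 100000 nM in this assay, at which 3 of the 4 values shown sit. On the carbonyl carbon, the change from 1-phenylcyclopropyl to isobutyl takes away both rings and goes from 9 heavy atoms to 4, yet compound 4 stays at the limit, as compound 1 does; the steps from compound 1 and from compound 2 to compound 4 cannot be read. The one readable step is an at least 15-fold higher number from compound 3 to compound 4 (1.18 log units; beyond the scatter), with isobutylcarbonyl in place of 4-chlorophenyl on an amine nitrogen in a ring, so among the compounds shown, compound 3 alone, with its 4-chlorophenyl, falls below the limit.

Going by these compounds, how far compound 1, compound 2 and compound 4 lie beyond the limit stays unknown, so nothing separates isobutyl from 1-phenylcyclopropyl on the carbonyl carbon. On these data alone, it also remains open whether a primary amine on a longer chain at the carbonyl carbon would stay at the limit, and whether an unsubstituted phenyl on the amine nitrogen in the ring would give a measured number, as 4-chlorophenyl does.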